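The source may report more compounds than this note shows. Statements on the series, on what has been measured and on what is new or still open speak of the compounds shown alone.

In an assay on cells for inhibition of HSP60/HSP10 (Homo sapiens), with a stated time of 60 min (a higher number here means a weaker inhibitor, a lower number a stronger inhibitor), compound 1 `O=S(=O)(Nc1ccc(-c2nc3ccccc3o2)cc1)c1ccc(Cl)s1` gives 31000 nM, the lowest of the two numbers recorded. Compound 2 `O=S(=O)(Nc1ccc2oc(-c3ccccc3)nc2c1)c1ccc(F)c(C(F)(F)F)c1` gives 69000 nM, a number that lies beyond the usual scatter from that of compound 1. Compound 3 `COc1cccc(S(=O)(=O)Nc2ccc3oc(-c4ccccc4)nc3c2)c1` gives only > 100000 nM, a limit of the assay and not a number. Compound 4 `O=S(=O)(Nc1ccc(-c2nc3ccccc3o2)cc1)c1ccccc1F` has not yet been measured in this assay. It differs from compound 1 in one place: 2-fluorophenyl in place of 5-chlorothiophen-2-yl on a sulfonyl sulfur. Among the compounds with values here, no measured pair shows a change at this position, so no step beyond the scatter is expected, with a slight weakening as the likelier direction. Compound 4 is expected to give 40000 nM, between 15000 nM and 100000 nM. The expected step of a 1.3-fold higher number from compound 1 to compound 4 (0.11 log units; within the scatter) is thus estimated to stay within the scatter.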

Compound 4, half-maximal inhibitory concentration: > 100000 nM
Compound 4: no number, only a limit (the forecaster's own chance of this, stated with the estimate: 30%); at least 2.5-fold (0.39 log units) between middle value and limit.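

In this assay, within the data shown here, the group on the sulfonyl sulfur is not interchangeable: 2-fluorophenyl in place of 5-chlorothiophen-2-yl gives an at least 3.2-fold higher number from compound 1 to compound 4 (0.50 log units; beyond the scatter), a change at this position that no earlier pair showed. Compound 4 gives only > 100000 nM, a limit of the assay and not a number, so the step has a lower bound but no measured size: the limit of > 100000 nM in this assay, at which 2 of the 4 values shown sit.

As far as these compounds go, whether the chlorine or the five-membered ring carries this step stays open. From the compounds shown here alone, how a plain thiophen-2-yl or an amine on the sulfonyl sulfur would read in this assay also stays open.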